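This account rests on a few compounds, and the source may have more. Where it says the series, first, only, none or still open, it means among the compounds named here.

compound 1 `COc1cccc(CCC(=O)Nc2nc3ccccc3c(=O)s2)c1`: 1370 nM
compound 2 `Cc1sc2nc(NC(=O)CCCc3ccccc3)sc(=O)c2c1C`: "not determined" (no result reported)
compound 3 `COc1cccc(/C=C/CC(=O)Nc2nc3ccccc3c(=O)s2)c1`: 500 nM

In an assay on CHO cells for displacement of a labelled ligand from adenosine receptor A1 (Homo sapiens), read by scintillation counting, with a stated time of 90 min (on this read-out higher numbers stand for weaker inhibition and lower numbers for stronger inhibition), compound 3 gives 500 nM, the lower of the two numbers in hand; the nearest, compound 1, sits clearly higher at 1370 nM, beyond the usual scatter. Compound 2 has no number in this assay, its entry being "not determined" (no result reported). Compound 4 `O=C(C/C=C/c1ccccc1)Nc1nc2ccccc2c(=O)s1` differs from compound 3 by hydrogen in place of methoxy on an aromatic carbon of a six-membered aromatic ring of carbon only, meta to a large group. Among the measured compounds shown here, no pair of measured compounds shows this change, so there is no direct reference. Removing the methoxy is expected to shift the number upward, by a step around or just beyond the scatter. The expected step is a 1.8-fold higher number from compound 3 to compound 4 (0.26 log units; within the scatter). Compound 4 is estimated at 900 nM in this assay, with a range from 350 nM to 2500 nM.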

Compound 4, inhibition constant: 822 nM
Estimate against measurement, compound 4: 1.1-fold (0.04 log units) above; low and high end bracket the measured number.
By their numbers in this assay, from the lowest: compounds 3, 4 and 1 (each within the scatter of the next, the first and the last beyond it).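

Hydrogen in place of methoxy on an aromatic carbon, meta to a large group, gives a 1.6-fold higher number from compound 3 to compound 4 (0.22 log units; within the scatter) in this assay. Among the compounds shown here, this is the first reading at this position, and on this core the methoxy is not required for a number of this order. Nothing on hand explains the step.

Open, from the compounds shown here alone, is whether a hydroxyl, an amine or a chlorine on this aromatic carbon would move the number beyond the scatter. Also open, going by these compounds, is whether the 3-methoxyphenyl to phenyl change gives a similar step with the chain of compound 1.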